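This account rests on a few compounds, and the source may have more. Where it says the series, first, only, none or still open, it means among the compounds named here.

Measured compounds:
compound 1, `Cc1ccc(N2C(=O)COc3ccc(-c4cnc5ccccc5c4)cc32)cc1`: > 40000 nM
compound 2, `O=C1COc2ccc(-c3cnc(Cl)c(NS(=O)(=O)c4ccc(F)cc4)c3)cc2N1c1ccc(F)cc1`: 34200 nM
compound 3, `O=C1COc2ccc(-c3cnc(Cl)c(NS(=O)(=O)c4ccc(F)cc4)c3)cc2N1C1CC1`: 12400 nM

In a functional assay on HCT-116 cells (Homo sapiens) for antiproliferative activity, read by MTT assay, with a stated time of 72 h (a lower number here means a stronger inhibitor, a higher number a weaker inhibitor), compound 1 reaches only the limit of the assay, > 40000 nM. Its standing among the three is therefore known only as that limit, (the limit of > 40000 nM in this assay, at which 1 of the 3 values shown sits). Compound 2 gives 34200 nM in this assay and compound 3 gives 12400 nM. For the measured compounds named here, the one measured step, a 2.8-fold lower number from compound 2 to compound 3 (0.44 log units; beyond the scatter), concerns the group on the amide-type nitrogen in the ring and does not touch the change followed here.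

Compound 4, `O=C1COc2ccc(-c3cnc4ccccc4c3)cc2N1c1ccc(F)cc1`, is compound 1 with a single change: fluoro in place of methyl on an aromatic carbon. Going by the values given here, no measured pair isolates this swap. Compound 2 carries the same 4-fluorophenyl on a different core and gives 34200 nM, but that is not a step from compound 1. With nothing showing an effect of the change, no step beyond the scatter is expected in this assay, and a limit remains likely. Compound 4 is expected at 40000 nM, with a range from 20000 nM to 80000 nM. The expected step is a number no higher from compound 1 to compound 4 (the limit leaves the size open).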

Compound 4, half-maximal inhibitory concentration: > 40000 nM
Compound 4 was reported as a limit; the forecaster's own chance of this, stated with the estimate: 60%; the middle value sits exactly at the limit.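

Compound 1 and compound 4 are both reported only as limits, so no step can be read between them: the limit of > 40000 nM in this assay, at which 2 of the 4 values shown sit.

The compounds shown leave open whether fluoro in place of methyl on an aromatic carbon changes the result at all in this assay.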